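A few compounds are considered here, and "the series" means these few. Any claim that something is new, unique, unknown or untested is made for them only; others in the source may bear on it.

Of the compounds shown here, two from this study have been measured in a functional assay on BGC-823 cells (Homo sapiens) for antiproliferative activity, read by MTT assay, tested at 1 uM; on this read-out lower numbers stand for a weaker effect and higher numbers for a stronger effect at the one concentration tested. Compound 1 `COc1ccc(C2OC(c3cc(OC)c(OC)c(OC)c3)=NN2C(C)=O)c(OC)c1` gives 6.3% in this assay, and compound 2 `COc1cc(C(=O)N/N=C/c2cccc(C(F)(F)F)c2)cc(OC)c1OC` gives 17.7%. Compound 1 thus stands at the lower of the two numbers, and compound 2 lies higher by a gap that is beyond the scatter of repeated measurements. Within the data shown here, no pair of measured compounds differs in only one place, so no single-step comparison is available to guide an expectation.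

Compound 3 `COc1ccc(OC)c(C2OC(c3cc(OC)c(OC)c(OC)c3)=NN2C(C)=O)c1` has not yet been measured in this assay. It is built from the same atoms as compound 1, joined differently: 2,5-dimethoxyphenyl in place of 2,4-dimethoxyphenyl on a saturated ring carbon. Among the measured compounds shown here, with no measured step to lean on, and with compound 1 sitting low on this read-out at 6.3%, the change is expected to move the number little, if at all, in either direction, and most likely not beyond the scatter. Compound 3 is therefore estimated to give 8% in this assay, within a range of 0% to 20%, which corresponds to an expected step of a number 1.7 percentage points higher from compound 1 to compound 3 (within the scatter).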

Compound 3, a percentage reported as inhibition, at one concentration (the size of the read-out at that concentration, not a potency): 0.4%
For compound 3 the middle estimate is 7.6 percentage points above the measured one; measured number inside the range.
By their numbers in this assay, from the lowest: compounds 3 and 1 (each within the scatter of the next); then compound 2.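

In this assay, among these compounds, putting 2,5-dimethoxyphenyl in place of 2,4-dimethoxyphenyl on the saturated ring carbon of the shared core gives a number 5.9 percentage points lower from compound 1 to compound 3 (within the scatter), and this is the first step that changes a single place. At this position, therefore, rearranging the same atoms, with the heavy-atom and hydrogen-bond acceptor counts unchanged, does not separate the two compounds on this read-out at the one concentration tested. Among the compounds shown here, nothing at hand offers an explanation for this result, and the single step does not show how other arrangements of the two methoxy groups would behave.

From the compounds shown here alone, whether this ring carbon accepts anything other than a dimethoxyphenyl group remains open: a phenyl ring carrying an amine or a carboxylic acid could move the number beyond the scatter, or could leave it where it is. Also open, going by these compounds, is whether the read-out responds to a change elsewhere on the core of compound 1, such as a longer chain in place of the acetyl group.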